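Chain homologation between the amide and the aminoanilide

The compounds below may be only part of what the source reports. "The series", "measured", "known", "first", "only" and "open" are said of these compounds alone.

For the measured compounds named here, compound 2 `Cn1cc(-c2ccccc2Oc2ccccc2)c2cc(C(=O)NCCCCCC(=O)Nc3ccccc3N)[nH]c2c1=O` carries the larger of the two numbers so far in a functional assay on MV4-11 cells (Homo sapiens) for antiproliferative activity, read by CCK-8 assay, with a stated time of 72 h; a higher number here means a weaker inhibitor, a lower number a stronger inhibitor; in this assay compound 2 gives 70 nM. Going by the values given here, the only comparator is compound 1 `Cn1cc(-c2cc(C(C)(C)O)ccc2OC2CC2)c2cc(C(=O)NCc3ccc(C(=O)Nc4ccccc4N)cc3)[nH]c2c1=O`, which in this assay gives 40 nM. The gap between these two lies within the scatter, so the pair is not separated and nothing is said about their order. Among the compounds with values here, no step between measured compounds isolates any single change, and nothing measured yet speaks to lengthening the saturated chain.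

Compound 3 `Cn1cc(-c2ccccc2Oc2ccccc2)c2cc(C(=O)NCCCCCCC(=O)Nc3ccccc3N)[nH]c2c1=O` differs from compound 2 by ((2-aminophenyl)carbamoyl)methyl in place of (2-aminophenyl)carbamoyl on a saturated chain carbon, five bonds along the chain from an amide-type nitrogen. A single added chain carbon of this kind is expected to move the number little, in no fixed direction, and the step from compound 2 to compound 3 is estimated at a 1.1-fold higher number from compound 2 to compound 3 (0.03 log units; within the scatter), inside the scatter. Compound 3 is therefore estimated at 75 nM, with a range from 30 nM to 190 nM.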

Compound 3, half-maximal inhibitory concentration: 130 nM
Compound 3: middle estimate off by 1.7-fold (0.24 log units), on the low side; the measured number falls inside the stated range.
By their numbers in this assay, from the lowest: compounds 1, 2 and 3 (each within the scatter of the next, the first and the last beyond it).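

For the compounds shown here, compound 3 supplies the only step so far that isolates one change, ((2-aminophenyl)carbamoyl)methyl in place of (2-aminophenyl)carbamoyl on a saturated chain carbon, and in this assay this reads a 1.9-fold higher number from compound 2 to compound 3 (0.27 log units; within the scatter). At this position, one added chain carbon therefore leaves compound 2 and compound 3 unseparated, and this single step sets no trend with chain length. Nothing available bears on the reason for this result.

From the compounds shown here alone, whether a shorter chain, or a longer chain such as 2-((2-aminophenyl)carbamoyl)ethyl at the same place, would give a step beyond the scatter stays open. Also open, going by these compounds, is how the chain length reads with a hydroxamic acid in place of the aminoanilide on the same shared core.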